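From 3-chlorophenyl to 4-iodophenyl on a shared core

The compounds below may be only part of what the source reports. "The series", "measured", "known", "first", "only" and "open" are said of these compounds alone.

Within the data shown here, in a functional assay on B16 cells (Mus musculus) for cytotoxicity, read by CCK-8 assay, with a stated time of 24 h (on this read-out lower numbers stand for stronger inhibition and higher numbers for weaker inhibition), compound 2 `COc1ccccc1Oc1c(N)nc(-c2cccc(Cl)c2)nc1OCCO` gives 5010 nM, the lower of the two numbers measured so far. The other number comes from compound 1 `COc1ccccc1Oc1c(N)nc(-c2ccccc2F)nc1OCCO`, which gives 11800 nM. Compound 2 is therefore the stronger inhibitor of the pair. The next compound, compound 3 `COc1ccccc1Oc1c(N)nc(-c2ccc(I)cc2)nc1OCCO`, carries 4-iodophenyl in place of 3-chlorophenyl on an aromatic carbon of the shared core (4-iodophenyl in place of 3-chlorophenyl on an aromatic carbon). Among the measured compounds shown here, only one measured step bears on this change: a 2.4-fold lower number from compound 1 to compound 2 (0.37 log units; beyond the scatter), with 3-chlorophenyl in place of 2-fluorophenyl on the same carbon. That step was modest, and a single step is thin evidence for a direction. No shift beyond the scatter is therefore expected in this assay, although a modest move either way remains possible. The expected change is a 1.3-fold lower number from compound 2 to compound 3 (0.10 log units; within the scatter). For compound 3 the estimated value is 4000 nM, with an expected range from 1500 nM to 11000 nM.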

Compound 3, half-maximal inhibitory concentration: 19600 nM
Compound 3: middle estimate off by 4.9-fold (0.69 log units), on the low side; measured number above the stated range.
By their numbers in this assay, from the lowest: compound 2; then compounds 1 and 3 (each within the scatter of the next).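

This carbon of the shared core does more than accept one halogen-bearing phenyl group in place of another. With a 3.9-fold higher number from compound 2 to compound 3 (0.59 log units; beyond the scatter), the number can also rise, so the advantage seen with 3-chlorophenyl does not carry over to 4-iodophenyl, and compound 3 cannot be told apart from compound 1, with a 1.7-fold higher number from compound 1 to compound 3 (0.22 log units; within the scatter), which leaves compound 2 as the strongest of the three in this assay. Nothing measured here explains why the number moves at this position.

The change from compound 2 to compound 3 alters both the halogen and its place on the phenyl ring, so the two contributions cannot be separated, and a 4-chlorophenyl or 3-iodophenyl group on this carbon would be needed to pull them apart. Also open, from the compounds shown here alone, is whether a phenyl group carrying an amine or a carboxylic acid instead of a halogen would give a lower number than compound 2.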